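A few compounds are considered here, and "the series" means these few. Any claim that something is new, unique, unknown or untested is made for them only; others in the source may bear on it.

Compound 1 `CC1CCN(C2CCN(S(=O)(=O)c3cccnc3Cl)CC2)CC1` carries the shared core with the 2-chloropyridin-3-yl group on the sulfonyl sulfur. In an ADME assay on HCT-116 cells (Homo sapiens) for cytotoxicity, read by CellTiter-Glo, with a stated time of 72 h (on this read-out higher numbers stand for weaker inhibition and lower numbers for stronger inhibition), compound 1 gives only a limit, > 10000 nM, and no number (the limit of > 10000 nM in this assay, at which 1 of the 2 values shown sits). Compound 2 `Cc1ccc(C#N)c(S(=O)(=O)N2CCC(N3CCC(C)CC3)CC2)c1` is the other measured member of the series. In this assay compound 2 likewise reaches only a limit, > 5000 nM (the limit of > 5000 nM in this assay, at which 1 of the 2 values shown sits). Going by the values given here, neither value is a number, so no measured step between the two can be stated; both compounds simply show no measurable cytotoxicity within the tested range. Compound 3 `CC1CCN(C2CCN(S(=O)(=O)c3cncc(Br)c3)CC2)CC1` is not yet measured. It differs from compound 1 in one place: 5-bromopyridin-3-yl in place of 2-chloropyridin-3-yl on a sulfonyl sulfur. Among the compounds with values here, no measured step covers this change; with both known values at limits, a step of no size beyond the scatter is expected in this assay, and the estimated step is a step that the limit leaves unreadable from compound 1 to compound 3. For compound 3 the expected half-maximal inhibitory concentration is 15000 nM with a range from 5000 nM to 50000 nM, most likely reported again as a limit rather than a number.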

Compound 3, half-maximal inhibitory concentration: > 10000 nM
Compound 3 was reported as a limit; the forecaster's own chance of this, stated with the estimate: 85%; the middle value does not contradict the limit.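

In this assay compound 3 gives > 10000 nM, a limit and not a number. Going by these compounds alone, compound 1 gives > 10000 nM, also a limit, so no step from compound 1 to compound 3 can be read. The compounds shown leave open whether any group on the sulfonyl sulfur gives a numerical half-maximal inhibitory concentration in this assay.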